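Amide side-chain swap at the carbonyl carbon: compound 4

The source may report more compounds than this note shows. Statements on the series, on what has been measured and on what is new or still open speak of the compounds shown alone.

Measured so far in an assay on HEK293 cells for displacement of a labelled ligand from Melanocortin receptor 4 (Homo sapiens); a higher number here means a weaker inhibitor, a lower number a stronger inhibitor:
compound 1 `CC(C)C[C@H](N)c1cc(Cl)ccc1N1CCN(C(=O)C(C)Cc2ccc(Cl)cc2)CC1` gives 67 nM
compound 2 `CC(C)C[C@H](N)c1cc(C(F)(F)F)ccc1N1CCN(C(=O)[C@H](C)Cc2ccc(Cl)cc2)CC1` gives 31 nM
compound 3 `COc1cc(Cl)ccc1CC(C)C(=O)N1CCN(c2ccc(Cl)cc2[C@@H](N)CC(C)C)CC1` gives 9.1 nM

Compound 2 stands second highest of the three numbers; compound 1 lies a little above it and compound 3 below it, both gaps beyond the scatter. Compound 4 `CC(C)C[C@H](N)c1cc(C(F)(F)F)ccc1N1CCN(C(=O)COc2cccc(Cl)c2)CC1` is the untested analogue; it differs from compound 2 in one place: (3-chlorophenoxy)methyl in place of 1-(4-chlorobenzyl)ethyl on a carbonyl carbon.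

Within the data shown here, the only step on record, a 7.4-fold lower number from compound 1 to compound 3 (0.87 log units; beyond the scatter), concerns a methoxy in place of hydrogen on an aromatic carbon, not the group on the carbonyl carbon, so it does not bear on this change. Among the measured compounds shown here, no measured pair probes the carbonyl substituent, and the replacement removes the defined stereocentre that compound 2 carries there. The expectation for compound 4 is therefore weakly grounded and leans toward a somewhat higher number, a 3.2-fold higher number from compound 2 to compound 4 (0.51 log units; beyond the scatter). Compound 4 is estimated at 100 nM, within 25 nM to 400 nM.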

Compound 4, inhibition constant: 2600 nM
Estimate against measurement, compound 4: 26-fold (1.41 log units) below; measured number above the stated range.
By their numbers in this assay, from the lowest: compound 3; then compound 2; then compound 1; then compound 4.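

In this assay, the group on the carbonyl carbon proves highly sensitive to change: (3-chlorophenoxy)methyl in place of 1-(4-chlorobenzyl)ethyl gives an 84-fold higher number from compound 2 to compound 4 (1.92 log units; beyond the scatter). Keeping a chlorine-bearing six-membered aromatic ring and a near-equal heavy-atom count therefore does not preserve the number, while the swap also adds an oxygen and removes the defined stereocentre. No available evidence accounts for this loss.

Which of these differences matters remains open. A 1-(3-chlorophenoxy)ethyl group would test the ether oxygen with the branching carbon restored.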